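This account rests on a few compounds, and the source may have more. Where it says the series, first, only, none or still open, it means among the compounds named here.

Compounds measured in a functional assay on MDA-MB-468 cells (Homo sapiens) for inhibition, read by sulforhodamine B assay, with a stated time of 48 h, tested at 1 uM; on this read-out higher numbers stand for a weaker effect at the one concentration tested and lower numbers for a stronger effect:
compound 1 `O=C(Nc1cccc(-n2cc(-c3ccncc3)c(-c3cc(O)cc(Cl)c3)n2)c1)Nc1ccc(Cl)c(C(F)(F)F)c1` gives 75%
compound 2 `COc1cc(Cl)cc(-c2nn(-c3cccc(NC(=O)Nc4ccc(Cl)c(C(F)(F)F)c4)c3)cc2-c2ccncc2)c1` gives 50%

Compound 2 stands lowest of the two numbers in this assay, set apart from compound 1 by the step of a number 25 percentage points lower from compound 1 to compound 2 (beyond the scatter). Compound 3 `COc1cc(Cl)cc(-c2nn(-c3cccc(NC(=O)c4cccc(C(F)(F)F)c4)c3)cc2-c2ccncc2)c1` differs from compound 2 by 3-(trifluoromethyl)phenyl in place of (4-chloro-3-(trifluoromethyl)phenyl)amino on a carbonyl carbon. For the measured compounds named here, no measured step touches this part of the molecule; the single measured step, a number 25 percentage points lower from compound 1 to compound 2 (beyond the scatter), concerns the oxygen on the aromatic ring and gives no guide here. The step from compound 2 to compound 3 is expected to be a number 30 percentage points higher from compound 2 to compound 3 (beyond the scatter), toward a weaker effect, with wide uncertainty. Compound 3 is therefore estimated at 80%, within 55% to 100%.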

Compound 3, a percentage reported as activity, at one concentration (the size of the read-out at that concentration, not a potency): 50%
For compound 3 the middle estimate is 30 percentage points above the measured one, outside the stated range (below it).
By their numbers in this assay, from the lowest: compounds 2 and 3 (each within the scatter of the next); then compound 1.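

In this assay, the step at the carbonyl carbon, 3-(trifluoromethyl)phenyl in place of (4-chloro-3-(trifluoromethyl)phenyl)amino, gives no change at the digits printed from compound 2 to compound 3 (within the scatter). This shows that the nitrogen, with its hydrogen-bond donor, and the chlorine can leave together without moving the read-out beyond the scatter, something the earlier step at the oxygen on the aromatic ring could not show. Nothing available explains this outcome. Going by these compounds, whether either the nitrogen or the chlorine matters on its own remains open. So does how a carboxylic acid or a morpholine on this carbonyl carbon would read.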